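The source may report more compounds than this note shows. Statements on the series, on what has been measured and on what is new or still open speak of the compounds shown alone.

So far only two compounds have numbers in a functional assay on HL-60 cells (Homo sapiens) for cytotoxicity, read by CCK-8 assay, with a stated time of 24 h (a lower number here means a stronger inhibitor, a higher number a weaker inhibitor), to compare. Compound 1 `C=CC(=O)N1C(=O)CC(c2ccc(C(F)(F)F)cc2)Sc2ccccc21` gives 106000 nM in this test, and compound 2 `C=CC(=O)N1C(=O)CC(C)Sc2ccccc21` gives 199000 nM in the same test. These two values lie within the usual scatter of repeated measurements, so compound 2 cannot be separated from compound 1 on these data. Compound 3 `C=CC(=O)N1C(=O)CCSc2ccccc21` has yet to be measured. It differs from compound 2 by hydrogen in place of methyl on a saturated ring carbon. Going by the values given here, no measured pair shows the effect of this change directly, so the forecast is uncertain. With so little to go on, no step beyond the scatter is expected. The estimated step of a 1.1-fold lower number from compound 2 to compound 3 (0.04 log units; within the scatter) is small and has no firm direction. In this assay, compound 3 is expected at 180000 nM with a likely range of 90000 nM to 380000 nM for now.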

Compound 3, half-maximal inhibitory concentration: 44800 nM
Compound 3: middle estimate off by 4.0-fold (0.60 log units), on the high side; the measured number lies below the stated range.
By their numbers in this assay, from the lowest: compound 3; then compounds 1 and 2 (each within the scatter of the next).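

Putting hydrogen in place of methyl on the saturated ring carbon next to the ring sulfur gives in this assay a 4.4-fold lower number from compound 2 to compound 3 (0.65 log units; beyond the scatter) as a modest step beyond the scatter. Going by these compounds alone, this is the first pair of compounds that differ only at this position, and it shows that the result is sensitive to what this carbon carries. Here, the compound without the methyl is the stronger inhibitor, but nothing shown gives a reason for the step.

As far as these compounds go, it remains open where an ethyl chain, a hydroxyl group or an amine on this same carbon would fall relative to hydrogen and methyl. From the compounds shown here alone, it is also open whether the same exchange would give a similar step on a core bearing other groups.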